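This account rests on a few compounds, and the source may have more. Where it says the series, first, only, none or still open, it means among the compounds named here.

Compound 1 `O=S(=O)(c1cc(Cl)cc(Cl)c1)c1cnc2c(F)cccc2c1-c1ccc(F)cc1` stands lowest of the three numbers in an ADME assay on microsomes from liver (Homo sapiens) for metabolic stability, tested at 2.5 uM (a higher number here means faster removal of the compound, a lower number slower removal), where compound 1 gives 1.01 mL/min. Compound 2 `COc1ccc(-c2c(S(=O)(=O)c3cc(Cl)cc(Cl)c3)cnc3c(F)cccc23)cc1` gives 2.11 mL/min, and compound 3 `O=S(=O)(c1cc(Cl)cc(Cl)c1)c1cnc2c(F)cccc2c1-c1cccc(F)c1` gives 1.08 mL/min. Among the measured steps, only a 2.1-fold higher number from compound 1 to compound 2 (0.32 log units; beyond the scatter) lies beyond the scatter, while a 1.1-fold higher number from compound 1 to compound 3 (0.03 log units; within the scatter) and a 2.0-fold lower number from compound 2 to compound 3 (0.29 log units; within the scatter) do not. Compound 4 `O=S(=O)(c1cccc(F)c1)c1cnc2c(F)cccc2c1-c1ccc(F)cc1` differs from compound 1 by 3-fluorophenyl in place of 3,5-dichlorophenyl on a sulfonyl sulfur. Going by the values given here, every measured step changes the aryl on the aromatic carbon, not the group on the sulfonyl sulfur, so none bears directly on this change, and with only one modest step seen in the whole set, the expectation in this assay is for no step beyond the scatter. Compound 4 is estimated at 1 mL/min, with a range from 0.5 mL/min to 2 mL/min. The step expected is a 1.0-fold lower number from compound 1 to compound 4 (0.00 log units; within the scatter).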

Compound 4, intrinsic clearance in a liver preparation (reported as CLH), per the amount of preparation that the assay uses: 0.19 mL/min
Compound 4: the middle estimate sits 5.3-fold (0.72 log units) above what was measured; the measured number lies below the stated range.
By their numbers in this assay, from the lowest: compound 4; then compounds 1, 3 and 2 (each within the scatter of the next, the first and the last beyond it).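

Going by these compounds alone, the group on the sulfonyl sulfur, untouched by the earlier steps, proves able to move the number in this assay: 3-fluorophenyl in place of 3,5-dichlorophenyl gives a 5.3-fold lower number from compound 1 to compound 4 (0.73 log units; beyond the scatter). This exceeds the largest change of the aryl on the aromatic carbon, a 2.1-fold higher number from compound 1 to compound 2 (0.32 log units; beyond the scatter). Nothing available explains the drop.

This single step cannot separate the loss of the two chlorines from the entry of the fluorine. As far as these compounds go, a plain phenyl or 3-chlorophenyl on the sulfonyl sulfur would bear on that, and how a pyridyl or a morpholine would behave there remains open.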